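Swapping tert-butyl for bromo on a cinnamoyl-acid scaffold

The source may report more compounds than this note shows. Statements on the series, on what has been measured and on what is new or still open speak of the compounds shown alone.

Of the compounds shown here, three with a shared core have been tested in a functional assay on K562 cells (Homo sapiens) for inhibition, read by MTT assay, with a stated time of 72 h; a higher number here means a weaker inhibitor, a lower number a stronger inhibitor. Compound 1 `Cc1cc(C2CCCCC2)c(C)cc1C(=O)/C=C/C(=O)O` gives 4240 nM. Compound 2 `CCc1cc(CC)c(C(=O)/C=C/C(=O)O)c(CC)c1` gives 4010 nM. Compound 3 `CC(C)(C)c1ccc(C(=O)/C=C/C(=O)O)cc1` gives 4330 nM. The value of compound 3 sits at the upper edge of the three, but its gaps to compound 1 and to compound 2 are both within the usual scatter, so the three compounds cannot be told apart on these numbers.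

The next compound, compound 4 `O=C(O)/C=C/C(=O)c1ccc(Br)cc1`, differs from compound 3 in one place: bromo in place of tert-butyl on an aromatic carbon. Within the data shown here, no pair of measured compounds shows what this kind of change does here, so the expectation rests only on the narrow spread of the three values seen so far.

The step of a 1.4-fold higher number from compound 3 to compound 4 (0.14 log units; within the scatter) is expected to be small, leaning if anything toward a weaker inhibitor. Compound 4 is therefore estimated at about 6000 nM, with a likely range from 2500 nM to 15000 nM.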

Compound 4, half-maximal inhibitory concentration: 11200 nM
Compound 4: middle estimate off by 1.9-fold (0.27 log units), on the low side; the range from low to high includes it.
By their numbers in this assay, from the lowest: compounds 2, 1 and 3 (each within the scatter of the next); then compound 4.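

In this assay, bromo in place of tert-butyl on this aromatic carbon gives a 2.6-fold higher number from compound 3 to compound 4 (0.41 log units; beyond the scatter) and so points toward a weaker inhibitor. Among these compounds, the earlier compounds could not be told apart and offered no single-place change, so this is the first sign that the group at this position can move the number beyond the scatter. Nothing at hand explains the size or direction of this step.

From the compounds shown here alone, a single exchange cannot separate the loss of tert-butyl from the gain of bromo, so it remains open which of the two matters. Other groups at this position, such as an amine, a methoxy group or a plain hydrogen, would show whether the number follows the size of the group or something specific to bromo.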